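A methyl for a bromo on compound 2

The source may report more compounds than this note shows. Statements on the series, on what has been measured and on what is new or still open speak of the compounds shown alone.

In an in vitro ADME assay on microsomes from liver (Homo sapiens) for metabolic stability, using NADPH (on this read-out lower numbers stand for slow clearance and higher numbers for fast clearance), compound 1 `CC(C)(CO)CNC(=O)c1cc2cc(C#N)ccc2n1Cc1cc(Cl)cc(Cl)c1` gives 103 mL.min-1.g-1 and compound 2 `COc1ccc(Br)cc1Cn1c(C(=O)NCC(C)(C)CO)cc2cc(C#N)ccc21` gives 104 mL.min-1.g-1. For the measured compounds named here, these two numbers lie within the scatter of each other, so compound 2 stands level with the only other compound measured. Compound 3 `COc1ccc(C)cc1Cn1c(C(=O)NCC(C)(C)CO)cc2cc(C#N)ccc21` has methyl in place of bromo on an aromatic carbon, para to a methoxy group: methyl in place of bromo on an aromatic carbon. This exchange has not itself been measured. Going by the values given here, the one measured step that bears on it is a 1.0-fold higher number from compound 1 to compound 2 (0.00 log units; within the scatter), where 5-bromo-2-methoxyphenyl takes the place of 3,5-dichlorophenyl, and that step lies within the scatter. On this single step, no shift beyond the scatter is expected in this assay, and no direction is favoured. The expected step is a 1.0-fold higher number from compound 2 to compound 3 (0.00 log units; within the scatter). Compound 3 is estimated at 105 mL.min-1.g-1, with an expected range of 60 mL.min-1.g-1 to 180 mL.min-1.g-1.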

Compound 3, intrinsic clearance in microsomes: 191 mL.min-1.g-1
Compound 3: the middle estimate sits 1.8-fold (0.26 log units) below what was measured; the whole stated range lies below it.
By their numbers in this assay, from the lowest: compounds 1, 2 and 3 (each within the scatter of the next).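

Methyl in place of bromo on an aromatic carbon, para to a methoxy group, now has a measured step of its own in this assay (a 1.8-fold higher number from compound 2 to compound 3 (0.26 log units; within the scatter)), so at this position the exchange of these two groups does not carry the number beyond the scatter. The 2-methoxy-5-methylphenyl and 3,5-dichlorophenyl groups also stay within it (a 1.9-fold higher number from compound 1 to compound 3 (0.27 log units; within the scatter)), which leaves compound 1, compound 2 and compound 3 without a separation on this read-out. Nothing shown here gives a reason for these numbers.

Going by these compounds, it remains open whether a different group at this position, such as an amine, a carboxylic acid or a longer chain, would give a step beyond the scatter. Also open, on these data alone, is whether the methoxy group, shared by compound 2 and compound 3, has any bearing on the outcome of this exchange.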